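Ring size at the chain end: a repeated swap

The source may hold more compounds than are shown below. What is called first, only, known or untested is meant among the compounds shown, and "the series" means these compounds.

Four compounds share one core and differ in two places. Compound 1 `COc1cc2c(Nc3ccc(C#N)cc3)ncnc2cc1OCCCN1CCCC1` and compound 2 `COc1cc2c(Nc3ccc(C#N)cc3)ncnc2cc1OCCCN1CCCCC1` carry the same aromatic amine, and compound 3 `COc1cc2c(Nc3ccccc3C#N)ncnc2cc1OCCCN1CCCC1` and compound 4 `COc1cc2c(Nc3ccccc3C#N)ncnc2cc1OCCCN1CCCCC1` carry another. In a functional assay on MCF7 cells (Homo sapiens) for antiproliferative activity, read by MTT assay, with a stated time of 72 h (a higher number here means a weaker inhibitor, a lower number a stronger inhibitor), compound 1 gives 16200 nM, compound 2 gives 35100 nM, and compound 3 gives 16200 nM. The change from compound 1 to compound 2 is piperidin-1-yl in place of pyrrolidin-1-yl on a saturated chain carbon, three bonds along the chain from an oxygen on an aromatic ring, and it gave a 2.2-fold higher number from compound 1 to compound 2 (0.34 log units; beyond the scatter). The cores of compound 1 and compound 3 differ by 2-cyanophenyl in place of 4-cyanophenyl on a nitrogen on an aromatic ring, which gave no change at the digits printed from compound 1 to compound 3 (within the scatter).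

Compound 4 is not yet measured. It differs from compound 3 by piperidin-1-yl in place of pyrrolidin-1-yl on a saturated chain carbon, three bonds along the chain from an oxygen on an aromatic ring, the same change as that from compound 1 to compound 2, made at the same place. Because a 2.2-fold higher number from compound 1 to compound 2 (0.34 log units; beyond the scatter) was modest and compound 3 sits level with compound 1, a step of similar size is expected from compound 3 to compound 4, namely a 2.2-fold higher number from compound 3 to compound 4 (0.33 log units; beyond the scatter). On that basis compound 4 is estimated at 35000 nM in this assay, with a likely range from 18000 nM to 70000 nM.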

Compound 4, half-maximal inhibitory concentration: 15200 nM
The estimate for compound 4 lay 2.3-fold (0.36 log units) above the measured number; measured number below the stated range.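

On the core of compound 3, piperidin-1-yl in place of pyrrolidin-1-yl gave a 1.1-fold lower number from compound 3 to compound 4 (0.03 log units; within the scatter) in this assay, while 2-cyanophenyl in place of 4-cyanophenyl on the core of compound 2 gave a 2.3-fold lower number from compound 2 to compound 4 (0.36 log units; beyond the scatter). The ring swap at the chain end therefore looks different on the two cores only at first sight, and the gap between its two steps is no firm sign that the core matters: the same change on two cores in this assay, a 2.2-fold higher number (0.34 log units; beyond the scatter) from compound 1 to compound 2 and a 1.1-fold lower number (0.03 log units; within the scatter) from compound 3 to compound 4, 2.3-fold (0.36 log units) apart, within the scatter of two such steps. Four compounds neither prove that either change carries over unaltered nor show that its effect depends on the core, and the same cautious reading applies to the swap of the cyanophenyl groups: the same change on two cores in this assay, no change at the digits printed (within the scatter) from compound 1 to compound 3 and a 2.3-fold lower number (0.36 log units; beyond the scatter) from compound 2 to compound 4, 2.3-fold (0.36 log units) apart, within the scatter of two such steps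

The compounds shown leave open how other groups at the chain end, such as a morpholine ring or a dimethylamino group, or a longer chain would behave on these two cores. They also leave open whether an aromatic amine carrying a chlorine atom or a methoxy group in place of the nitrile would follow the same picture.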